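Moving the substituent on compound 3's aryl amide

A few compounds are considered here, and "the series" means these few. Any claim that something is new, unique, unknown or untested is made for them only; others in the source may bear on it.

Compound 3 `CN(C)c1nc(N[C@H]2CC[C@@H](NC(=O)c3ccccc3F)CC2)nc2ccccc12` gives 170 nM in an assay on HEK293 cells for inhibition of melanin-concentrating hormone receptor 1 (Homo sapiens), read by radioligand binding (on this read-out higher numbers stand for weaker inhibition and lower numbers for stronger inhibition), the highest number among the three measured compounds. Its nearest neighbour is compound 1 `CN(C)c1nc(N[C@H]2CC[C@@H](NC(=O)c3ccc(F)c(F)c3F)CC2)nc2ccccc12` with 38 nM; the step is a 4.5-fold higher number from compound 1 to compound 3 (0.65 log units; beyond the scatter). Compound 2 `CN(C)c1nc(N[C@H]2CC[C@@H](NC(=O)c3cccc(F)c3)CC2)nc2ccccc12` gives 9.5 nM, and the step of an 18-fold higher number from compound 2 to compound 3 (1.25 log units; beyond the scatter) is the largest seen. Compound 4 `CN(C)c1nc(N[C@H]2CC[C@@H](NC(=O)c3cccc(C#N)c3)CC2)nc2ccccc12` differs from compound 3 by 3-cyanophenyl in place of 2-fluorophenyl on a carbonyl carbon. The step from compound 2 to compound 3 bears most on this, since it also exchanges a 3-substituted for a 2-substituted ring, and it was large. Whether a nitrile matches a fluorine at that site is not shown, so some of that gain may not return. Compound 4 is therefore expected to give 20 nM (range 5 nM to 80 nM), an expected step of an 8.5-fold lower number from compound 3 to compound 4 (0.93 log units; beyond the scatter).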

Compound 4, half-maximal inhibitory concentration: 10 nM
Compound 4: the middle estimate sits 2.0-fold (0.30 log units) above what was measured, within the range that was stated.
By their numbers in this assay, from the lowest: compounds 2 and 4 (each within the scatter of the next); then compound 1; then compound 3.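

In this assay, cyano in place of fluoro on an aromatic carbon gives a 1.1-fold higher number from compound 2 to compound 4 (0.02 log units; within the scatter), so the 3-fluorophenyl level does not depend on fluorine alone. The nitrile also stands clear of the other two rings, with a 17-fold lower number from compound 3 to compound 4 (1.23 log units; beyond the scatter) and a 3.8-fold lower number from compound 1 to compound 4 (0.58 log units; beyond the scatter). Nothing available here explains why the two 3-substituted rings match. Still open, on these data alone, is whether a methoxy group, a chlorine atom or an amine on the 3-substituted ring would keep this level. Also open, as far as these compounds go, is whether 2-cyanophenyl would give a number as high as 2-fluorophenyl does.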